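Swapping the thiophene for a trifluoromethyl-bearing phenyl ring

The source may hold more compounds than are shown below. What is called first, only, known or untested is meant among the compounds shown, and "the series" means these compounds.

Compounds measured:
Compound 1, `c1ccc(-c2cn3ccnc3c(-c3ccc4ncn(C5CCCCC5)c4c3)n2)cc1`, gives 67.1%.
Compound 2, `c1csc(-c2cn3ccnc3c(-c3ccc4ncn(C5CCCCC5)c4c3)n2)c1`, gives 26.6%.

Both numbers come from a functional assay on HL-60 cells (Homo sapiens) for inhibition, read by sulforhodamine B assay, with a stated time of 48 h, tested at 10 uM; a lower number here means less inhibition, a higher number more inhibition at the concentration tested (going by the name of the read-out). Compound 1 carries a plain phenyl ring on the shared core, while compound 2 carries a thiophen-2-yl ring in its place. Of the two numbers, compound 2 stands lowest; the step of a number 40.5 percentage points lower from compound 1 to compound 2 (beyond the scatter) is large and lies beyond the usual scatter, so the exchange of phenyl for thiophen-2-yl clearly lowered the read-out.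

Compound 3, `FC(F)(F)c1cccc(-c2cn3ccnc3c(-c3ccc4ncn(C5CCCCC5)c4c3)n2)c1`, has not yet been tested. It differs from compound 2 in one place: 3-(trifluoromethyl)phenyl in place of thiophen-2-yl on an aromatic carbon. For the measured compounds named here, the only measured step that bears on this change is a number 40.5 percentage points lower from compound 1 to compound 2 (beyond the scatter), in which the thiophen-2-yl ring replaced a six-membered carbon ring and the number fell sharply. Going by the values given here, compound 3 reverses that exchange, returning to a six-membered carbon ring, though one now bearing a trifluoromethyl group whose effect no measured pair shows. A rise in this assay is therefore expected, of about the size a number 28.4 percentage points higher from compound 2 to compound 3 (beyond the scatter). Compound 3 is estimated to give 55%, within the range 30% to 80%.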

Compound 3, a percentage reported as inhibition, at one concentration (the size of the read-out at that concentration, not a potency): 1.06%
Beside the measured number, compound 3's estimate is 53.9 percentage points above it; the whole stated range lies above it.
By their numbers in this assay, from the lowest: compound 3; then compound 2; then compound 1.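

At this position, a return to a six-membered carbon ring does not by itself restore the read-out in this assay. Instead, the 3-(trifluoromethyl)phenyl group falls short even of the thiophen-2-yl ring, with a number 25.5 percentage points lower from compound 2 to compound 3 (beyond the scatter) in this modest but real step. The sharper lesson comes from the comparison with the plain phenyl ring, where trifluoromethyl replaces a single hydrogen and the result is a number 66 percentage points lower from compound 1 to compound 3 (beyond the scatter) in a large step that leaves compound 3 at 1.06% as its level of inhibition, so one added group on the ring can matter more here than the exchange of one ring for another. Nothing available explains why this added group has such an effect.

Going by these compounds, it remains open whether this loss is specific to trifluoromethyl, or whether a methyl group, a chlorine atom or an amine on the same phenyl ring would also lower the read-out. These percentages also come from a single tested concentration, so they leave open how the potencies of the three compounds compare across a range of concentrations.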